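Removing the fluorophenyl ring from the aryl substituent of compound 1

The source may report more compounds than this note shows. Statements on the series, on what has been measured and on what is new or still open speak of the compounds shown alone.

Compound 1 `CN(C)CCCCCSC1=Nc2ccccc2C(CC(=O)NCc2ccccc2)N1c1ccc(-c2ccc(F)cc2)cc1` gives the lowest number of the three measured compounds in an assay on cells for inhibition of Voltage-dependent T-type calcium channel subunit alpha-1G (Homo sapiens), read by patch clamp (on this read-out lower numbers stand for stronger inhibition and higher numbers for weaker inhibition), at 250 nM. Its nearest neighbour is compound 3 `O=C(CC1c2ccccc2N=C(SCCCCCN2CCCC2)N1c1ccc(-c2ccc(F)cc2)cc1)NCc1ccccc1`, which gives 2180 nM in this assay; the furthest is compound 2 `O=C(CC1c2ccccc2N=C(SCCCCCN2CCCC2)N1c1ccc(-c2ccc(F)cc2)cc1)NCc1ccc(F)cc1`, at 12600 nM. The step of an 8.7-fold higher number from compound 1 to compound 3 (0.94 log units; beyond the scatter) shows the amine change, and the step of a 5.8-fold lower number from compound 2 to compound 3 (0.76 log units; beyond the scatter) shows the fluoro-to-hydrogen change on the benzylamide ring.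

Compound 4 `CN(C)CCCCCSC1=Nc2ccccc2C(CC(=O)NCc2ccccc2)N1c1ccccc1` differs from compound 1 by hydrogen in place of 4-fluorophenyl on an aromatic carbon. Among the measured compounds shown here, none of the measured steps alters this part of the shared core: the amine change and the fluoro change both leave the aryl substituent untouched, so no direct reference exists for removing a whole aromatic ring there. The change is structurally larger than either measured step, and both measured steps away from compound 1 raised the number. A rise in this assay is therefore expected, with wide uncertainty, estimated as a 6.0-fold higher number from compound 1 to compound 4 (0.78 log units; beyond the scatter). For compound 4 the expected value in this assay is 1500 nM, with a range from 300 nM to 8000 nM.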

Compound 4, half-maximal inhibitory concentration: 18500 nM
Compound 4: middle estimate off by 12-fold (1.09 log units), on the low side, and the stated range ends below it.
By their numbers in this assay, from the lowest: compound 1; then compound 3; then compounds 2 and 4 (each within the scatter of the next).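

In this assay, among the compounds shown here, hydrogen in place of 4-fluorophenyl gives a 74-fold higher number from compound 1 to compound 4 (1.87 log units; beyond the scatter), the first reading at this aromatic carbon of the shared core, and it shows that the outer aromatic ring cannot be dropped here without a large loss of inhibition. This step exceeds both the amine change, an 8.7-fold higher number from compound 1 to compound 3 (0.94 log units; beyond the scatter), and the fluoro change on the benzylamide ring, a 5.8-fold lower number from compound 2 to compound 3 (0.76 log units; beyond the scatter), so among the single changes shown, this place is the most sensitive on the read-out. No accompanying data bear on the result, and the size of the step stands without an explanation.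

The compounds shown leave open whether the ring itself or its fluoro substituent carries the effect: an unsubstituted phenyl at this place, or a smaller group such as methyl or chloro, would separate the two. Also open, going by these compounds, is whether the same removal of 4-fluorophenyl carries over to the pyrrolidin-1-yl amine of compound 3, which would show whether the amine change and the ring change add up or depend on each other.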